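A few compounds are considered here, and "the series" means these few. Any claim that something is new, unique, unknown or untested is made for them only; others in the source may bear on it.

Measured so far:
compound 1, `COc1ccccc1C#Cc1nc2c(s1)C(=O)NCC2`: > 10000 nM
compound 2, `CC(C)CN1CCc2nc(C#Cc3ccccc3)sc2C1`: > 10000 nM
compound 3, `C(#Cc1nc2c(s1)CN(C1CCCCC1)CC2)c1ccccc1`: > 10000 nM

Each of these three values is a limit of an assay on HEK293 cells for positive allosteric modulation of metabotropic glutamate receptor 5 (Homo sapiens), read by FLIPR, with a stated time of 1 h (on this read-out higher numbers stand for an effect only at larger amounts of compound and lower numbers for an effect already at smaller amounts), and not a number. Compound 1 sits at the limit of this assay. Compound 2 sits at the limit as well. Compound 3 also sits at the limit, so where it stands on the shown numbers is unknown beyond the fact that its half-maximal effective concentration lies past that limit, as the limit of > 10000 nM in this assay, at which 3 of the 3 values shown sit, records for every value shown. The step that the two limits leave unreadable from compound 2 to compound 3 is accordingly unreadable, both of its ends being limits.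

Compound 4, `CC1CC1C(=O)N1CCc2nc(C#Cc3ccccc3)sc2C1`, differs from compound 3 in one place: (2-methylcyclopropyl)carbonyl in place of cyclohexyl on an amine nitrogen in a ring. For the measured compounds named here, no measured step bears on this change. Going by the values given here, the only step in the set, a step that the two limits leave unreadable from compound 2 to compound 3, exchanges one hydrocarbon group on the same nitrogen for another and gives no readable size; no carbonyl on that nitrogen has been measured at all. Among the compounds with values here, an expectation can rest on no more than the observation that every compound so far shows no effect within the range of this assay. The expected step of an at least 2.0-fold lower number from compound 3 to compound 4 (0.30 log units; that floor lies within the scatter) is set as a tentative gain with wide uncertainty, and compound 4 is estimated at 5000 nM, between 500 nM and 50000 nM, with a substantial chance that only a limit is again reported.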

Compound 4, half-maximal effective concentration: 9.4 nM
Compound 4: the middle estimate sits 530-fold (2.73 log units) above what was measured; the measured number lies below the stated range.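

In this assay, an amine nitrogen in a ring proves to be a place that can decide whether the series shows any effect: exchanging a hydrocarbon group there for (2-methylcyclopropyl)carbonyl gives an at least 1000-fold lower number from compound 3 to compound 4 (3.02 log units; beyond the scatter) and an at least 1000-fold lower number from compound 2 to compound 4 (3.02 log units; beyond the scatter). Both sizes are floors rather than exact figures, because one end of each step is a limit: the limit of > 10000 nM in this assay, at which 3 of the 4 values shown sit. Cyclohexyl and (2-methylcyclopropyl)carbonyl have the same count of heavy atoms, so that count alone does not separate compound 3 from compound 4; they differ in the carbonyl, with its hydrogen-bond acceptor, and in a three-membered ring in place of a six-membered one.

Since compound 4 brings in the carbonyl and the 2-methylcyclopropyl group together, the compounds shown do not tell which of the two accounts for the gain, or whether both are needed. On these data alone, a cyclopropylmethyl group on the same nitrogen would test the ring without the carbonyl, an acetyl group would test the carbonyl without the ring, and what either would give remains open.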